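A few compounds are considered here, and "the series" means these few. Any claim that something is new, unique, unknown or untested is made for them only; others in the source may bear on it.

Of the compounds shown here, three sharing one core have been measured in an assay on HEK293 cells for inhibition of Voltage-dependent T-type calcium channel subunit alpha-1G (Homo sapiens), read by fluorescence, tested at 10 uM; on this read-out higher numbers stand for more inhibition at the one concentration tested (going by the name of the read-out) and lower numbers for less inhibition. Compound 1 `CCCc1nc(-c2ccccc2)c(CNCCN2CCN(C(c3ccccc3)c3ccccc3)CC2)o1` gives 71.9%. Compound 2 `CCCc1nc(-c2ccccc2)c(CNCCCN2CCN(c3cccc(C)c3)CC2)o1` gives 47.8%. Compound 3 `CCCc1nc(-c2ccccc2)c(CNCCN2CCN(c3ccccc3)CC2)o1` gives 54.3%. On these numbers compound 2 and compound 3 lie within the scatter of each other, so no order between them can be read, while compound 1 stands beyond the scatter above compound 2. Compound 4 `CCCc1nc(-c2ccccc2)c(CNCCCN2CCN(c3ccc(OC)cc3)CC2)o1` has not yet been measured. It differs from compound 2 in one place: 4-methoxyphenyl in place of 3-methylphenyl on an amine nitrogen in a ring. Within the data shown here, no step between two measured compounds covers a change of this kind, so nothing in the numbers so far tells how an exchange on the amine nitrogen in a ring moves the read-out. The expected step of a number 0.2 percentage points higher from compound 2 to compound 4 (within the scatter) is therefore taken as none beyond the scatter. In this assay compound 4 is estimated to give 48%, expected to fall between 30% and 66%.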

Compound 4, a percentage reported as inhibition, at one concentration (the size of the read-out at that concentration, not a potency): 42.1%
Estimate against measurement, compound 4: 5.9 percentage points above; the range from low to high includes it.
By their numbers in this assay, from the lowest: compounds 4, 2 and 3 (each within the scatter of the next, the first and the last beyond it); then compound 1.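

In this assay, 4-methoxyphenyl in place of 3-methylphenyl on the amine nitrogen in a ring gives a number 5.7 percentage points lower from compound 2 to compound 4 (within the scatter), so this position now has one readable exchange. At this position, then, a group with one more heavy atom, an oxygen and a hydrogen-bond acceptor leaves the read-out within the scatter, at least for this pair. Nothing measured on these compounds speaks to the cause of this outcome.

The exchange alters both the group on the aromatic ring and the name's ring position at once, so the compounds shown cannot separate the two; 3-methoxyphenyl or 4-methylphenyl on the same nitrogen would be needed for that. They also leave open how a group of another kind, such as a pyridyl ring or a benzyl group, would read there.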